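The compounds below may be only part of what the source reports. "The series", "measured", "known", "first", "only" and "open" are said of these compounds alone.

Within the data shown here, compound 2 `C[n+]1cccc(OP(=O)([O-])OC[C@H]2O[C@@H](n3cc(F)c(=O)[nH]c3=O)C[C@@H]2OC(=O)c2ccccc2)c1` carries the highest of the two numbers measured so far in a functional assay on U-118-MG cells (Homo sapiens) for cytotoxicity, read by MTT assay, with a stated time of 48 h (on this read-out higher numbers stand for weaker inhibition and lower numbers for stronger inhibition), where compound 2 gives 3150 nM. Among the measured compounds shown here, its nearest neighbour is compound 1 `O=C(O[C@H]1C[C@H](n2cc(F)c(=O)[nH]c2=O)O[C@@H]1COP(=O)(O)Oc1ccccc1)c1ccccc1`, which in this assay gives 970 nM; the one measured step, a 3.2-fold higher number from compound 1 to compound 2 (0.51 log units; beyond the scatter), lies beyond the scatter. Compound 3 `C[N+]1(C)CCC(OP(=O)([O-])OC[C@H]2O[C@@H](n3cc(F)c(=O)[nH]c3=O)C[C@@H]2OC(=O)c2ccccc2)CC1` differs from compound 2 in one place: a group of 8 heavy atoms (7 carbon, 1 nitrogen; one six-membered non-aromatic ring with 1 hetero atom) in place of a group of 7 heavy atoms (6 carbon, 1 nitrogen; one six-membered aromatic ring with 1 hetero atom), on an oxygen. For the measured compounds named here, no measured step follows this kind of exchange; the only step known, a 3.2-fold higher number from compound 1 to compound 2 (0.51 log units; beyond the scatter), concerns a different replacement and gives no direct guide. With one compound on each side of that step and nothing known for the entering group, the expectation for compound 3 rests on the assumption that swapping one ring of net charge +1 for another leaves the number close to that of compound 2. The step from compound 2 to compound 3 in this assay is therefore expected to be small, a 1.1-fold higher number from compound 2 to compound 3 (0.05 log units; within the scatter), and to stay within the scatter in either direction. Compound 3 is estimated at 3500 nM in this assay, with a range from 1200 nM to 10000 nM.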

Compound 3, half-maximal inhibitory concentration: 4420 nM
Compound 3: middle estimate off by 1.3-fold (0.10 log units), on the low side; the measured number falls inside the stated range.
By their numbers in this assay, from the lowest: compound 1; then compounds 2 and 3 (each within the scatter of the next).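

At the place on an oxygen whose other neighbours are phosphorus, replacing the six-membered aromatic ring with 1 hetero atom by the six-membered non-aromatic ring with 1 hetero atom left the number in this assay within the scatter (a 1.4-fold higher number from compound 2 to compound 3 (0.15 log units; within the scatter)). Both groups carry a net charge of +1, so in these two compounds, aromatic or not, the ring type gave no readable difference, which compound 1 and compound 2 alone could not show. The comparison with the carbon-only aromatic ring of compound 1 now holds for two exchanges in the same direction, each beyond the scatter (a 3.2-fold higher number from compound 1 to compound 2 (0.51 log units; beyond the scatter); a 4.6-fold higher number from compound 1 to compound 3 (0.66 log units; beyond the scatter)), yet nothing shown accounts for this.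

These compounds do not separate the effect of the charge from that of the ring, since no uncharged piperidine bearing a tertiary amine stands among them at this place. On these data alone, it also remains open how an open-chain group such as a trimethylammonium ethyl chain, or a carboxylic acid on a short chain, would read in this assay on the same core.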